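Adding a hydroxy group to a well-tolerated compound

The compounds below may be only part of what the source reports. "The series", "measured", "known", "first", "only" and "open" are said of these compounds alone.

In an ADME assay on HEK293 cells (Homo sapiens) for cytotoxicity, read by reporter gene assay and resazurin assay, with a stated time of 48 h (a lower number here means that less compound is tolerated, a higher number that more compound is tolerated), compound 3 `COc1ccccc1C(=O)Nc1ccc(Sc2nc3ccccc3s2)cc1` gives > 100000 nM, which is a limit and not a number. Compound 4 `O=C(Nc1ccc(Sc2nc3ccccc3s2)cc1)c1cccc(Br)c1O` has 3-bromo-2-hydroxyphenyl in place of 2-methoxyphenyl on a carbonyl carbon.

Within the data shown here, one measured step bears on this change, and it comes from a smaller pair of compounds. Compound 1 `O=C(Nc1ccccc1)c1cc(Br)ccc1O` carries a hydroxy group and gives 35000 nM. Compound 2 `O=C(Nc1ccccc1)c1cccc(Br)c1`, with hydrogen in place of that hydroxy, gives > 100000 nM, which is also a limit. The measured change is an at least 2.8-fold higher number from compound 1 to compound 2 (0.45 log units; beyond the scatter). Only compound 1 has a true number here, and the others rest on (the limit of > 100000 nM in this assay, at which 2 of the 3 values shown sit).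

Read in reverse, this single step suggests that gaining the hydroxy group may lower the number, so that less compound is tolerated. The expected change is an at least 5.0-fold lower number from compound 3 to compound 4 (0.69 log units; beyond the scatter), and its size is uncertain. Compound 4 is therefore estimated at 20000 nM, with an expected range from 5000 nM to 70000 nM.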

Compound 4, half-maximal cytotoxic concentration: 71000 nM
Compound 4: the middle estimate sits 3.6-fold (0.55 log units) below what was measured; the whole stated range lies below it.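

On this larger core, the swap on the carbonyl carbon gives the first true number, and in this assay the step is an at least 1.4-fold lower number from compound 3 to compound 4 (0.14 log units; that floor lies within the scatter). That floor does not establish a real drop, so gaining 3-bromo-2-hydroxyphenyl in place of 2-methoxyphenyl may change tolerance only slightly here, and compound 4 shows that a hydroxy-bearing compound on this core can still read high. The true size of the step remains unknown because compound 3 has only a limit: the limit of > 100000 nM in this assay, at which 2 of the 4 values shown sit.

The swap changes more than one feature at once, so the compounds shown cannot separate the contribution of the bromine from that of the hydroxy group. They also leave open how the number would respond to an amine or a carboxylic acid on that phenyl ring.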